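From a phenyl amine to a pyrrolidine on one core

The compounds below may be only part of what the source reports. "The series", "measured", "known", "first", "only" and "open" are said of these compounds alone.

In a functional assay on MCF7 cells (Homo sapiens) for inhibition, read by sulforhodamine B assay (a lower number here means a stronger inhibitor, a higher number a weaker inhibitor), compound 3 (`COc1ccccc1NC1=CC(=O)c2c(nc3n2[C@H]2OC[C@@H](O)[C@H]2OC3)C1=O`) gives 6580 nM, and compound 2 (`O=C1C(Nc2ccc(Br)cc2)=CC(=O)c2c1nc1n2[C@H]2OC[C@@H](O)[C@H]2OC1`) gives 4330 nM. Compound 1 (`O=C1C(Nc2ccccc2)=CC(=O)c2c1nc1n2[C@H]2OC[C@@H](O)[C@H]2OC1`) gives only a limit of the assay, > 4000 nM. Its two steps, a step that the limit leaves unreadable from compound 1 to compound 2 and a step that the limit leaves unreadable from compound 1 to compound 3, therefore offer no size to work from.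

Compound 4 (`O=C1C(N2CCCC2)=CC(=O)c2c1nc1n2[C@H]2OC[C@@H](O)[C@H]2OC1`) carries pyrrolidin-1-yl in place of (2-methoxyphenyl)amino on a double-bonded ring carbon. Among the compounds with values here, no measured step makes this kind of swap. Within the data shown here, the only readable step, a 1.5-fold higher number from compound 2 to compound 3 (0.18 log units; within the scatter), exchanges one substituted phenyl group for another, so no change beyond the scatter is expected, in either direction. The expected step is a 1.3-fold lower number from compound 3 to compound 4 (0.12 log units; within the scatter). For compound 4 the estimated value is 5000 nM, with an expected range from 1500 nM to 15000 nM.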

Compound 4, half-maximal inhibitory concentration: > 16000 nM
Compound 4 was reported as a limit (the forecaster's own chance of this, stated with the estimate: 30%); at least 3.2-fold (0.50 log units) between middle value and limit.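

Within the data shown here, putting pyrrolidin-1-yl on this double-bonded ring carbon gives the first change beyond the scatter in this assay, with an at least 2.4-fold higher number from compound 3 to compound 4 (0.38 log units; beyond the scatter) and an at least 3.6-fold higher number from compound 2 to compound 4 (0.56 log units; beyond the scatter) as the weaker direction. Compound 4 is reported only as a limit: the limit of > 16000 nM in this assay, at which 1 of the 4 values shown sits. All steps from compound 1 cannot be read.

Compound 4 loses the aromatic ring and the amine hydrogen together, so the compounds shown cannot separate the two. On these data alone, how morpholine or an open-chain amine such as dimethylamino would behave on this carbon also remains open.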